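Exchanging a Dimethylamino Group for Methylsulfonyl

The source may report more compounds than this note shows. Statements on the series, on what has been measured and on what is new or still open speak of the compounds shown alone.

Among the measured compounds shown here, compound 1 `CN(C)c1ccc(-c2cc(C(=O)N[C@H]3CCCNC3)c(NC(N)=O)s2)cc1` is the only compound here with a number to its name: in an assay on isolated protein for inhibition of cyclin-dependent kinase 2-associated protein 1 (Homo sapiens) (a lower number here means a stronger inhibitor, a higher number a weaker inhibitor), compound 1 gives 8400 nM, which places it among weak inhibitors. Compound 2 `CC(=O)Nc1cccc(-c2cc(C(=O)N[C@H]3CCCNC3)c(NC(N)=O)s2)c1` shares the same core with a different substituent, and for compound 2 this assay reports "not determined" (no result reported), so it offers no comparison. Compound 3 `CS(=O)(=O)c1ccc(-c2cc(C(=O)N[C@H]3CCCNC3)c(NC(N)=O)s2)cc1` is the untested relative of compound 1. The difference between them is methylsulfonyl in place of dimethylamino on an aromatic carbon. For the measured compounds named here, with a single number in hand, no step between measured compounds exists to lean on, so the size and direction of this change cannot be read from the data and can only be guessed. The expected step is a 1.2-fold higher number from compound 1 to compound 3 (0.08 log units; within the scatter), which is no larger than the usual scatter, in either direction. Compound 3 is therefore estimated at 10000 nM in this assay, with a plausible range from 3000 nM to 30000 nM.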

Compound 3, half-maximal inhibitory concentration: 2200 nM
Compound 3: middle estimate off by 4.5-fold (0.66 log units), on the high side; the whole stated range lies above it.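

In this assay, the spot on the six-membered aromatic ring para to a large group responds to what sits there: methylsulfonyl in place of dimethylamino gives a 3.8-fold lower number from compound 1 to compound 3 (0.58 log units; beyond the scatter), a modest step. Among the compounds shown here, this is the first sign that the substituent at this position matters, and it also shows that dimethylamino is not required for inhibition, since compound 3 lacks it and has the lower number. Nothing available here explains why the number falls.

A single step cannot show whether this gain is particular to methylsulfonyl or would also appear with other groups at this spot, such as a methoxy group, a carboxylic acid or a simple amine. For the compounds shown here, compound 2 has no number, so no step involving it can be read.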